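This account rests on a few compounds, and the source may have more. Where it says the series, first, only, none or still open, it means among the compounds named here.

Measured in a functional assay on 2008 cells (Homo sapiens) for cytotoxicity, read by MTT assay, with a stated time of 68 h; a lower number here means a stronger inhibitor, a higher number a weaker inhibitor:
- compound 1 `O=C(/C=C/c1cccc(OCc2ccccc2)c1)c1ccc(Br)cc1`: 1000 nM
- compound 2 `O=C(/C=C/c1cccc(OCc2ccccc2)c1)c1ccc(Cl)cc1`: 20000 nM
- compound 3 `O=C(/C=C/c1cccc(OCc2ccccc2)c1)c1ccccc1Br`: 1200 nM

Compound 3 lies within the scatter of compound 1 and far from compound 2. Compound 4 `O=C(/C=C/c1cccc(OCc2ccccc2)c1)c1cccc(Br)c1` carries 3-bromophenyl in place of 2-bromophenyl on a carbonyl carbon. Among the compounds with values here, the closest precedent is 2-bromophenyl in place of 4-bromophenyl, a 1.2-fold higher number from compound 1 to compound 3 (0.08 log units; within the scatter). Both large steps, a 20-fold higher number from compound 1 to compound 2 (1.30 log units; beyond the scatter) and a 17-fold lower number from compound 2 to compound 3 (1.22 log units; beyond the scatter), involve the chloro group, which compound 4 lacks. Within the data shown here, no step beyond the scatter is therefore expected in this assay, although no measured compound yet carries 3-bromophenyl. The estimated step is no change at the digits printed from compound 3 to compound 4 (within the scatter). Compound 4 is expected at 1200 nM, with an estimated range of 400 nM to 4000 nM.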

Compound 4, half-maximal inhibitory concentration: 5700 nM
Compound 4: middle estimate off by 4.8-fold (0.68 log units), on the low side; the measured number lies above the stated range.
By their numbers in this assay, from the lowest: compounds 1 and 3 (each within the scatter of the next); then compound 4; then compound 2.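

In this assay, the position of the bromine on the phenyl at the carbonyl carbon now matters: with a 4.8-fold higher number from compound 3 to compound 4 (0.68 log units; beyond the scatter) and a 5.7-fold higher number from compound 1 to compound 4 (0.76 log units; beyond the scatter) as the two steps, 3-bromophenyl parts from the 2-bromophenyl and 4-bromophenyl pair, which lie within the scatter of each other. Bromine alone therefore does not set the number, although a 3.5-fold lower number from compound 2 to compound 4 (0.55 log units; beyond the scatter) still favours 3-bromophenyl over 4-chlorophenyl. No measurement available here bears on the reason for this shift. Open, as far as these compounds go, is whether 2-chlorophenyl and 3-chlorophenyl would track their bromo counterparts. Also open, from the compounds shown here alone, is whether a methoxy or dimethylamino group on the same phenyl would match compound 1.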